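Notes on removing one chloro from compound 2

This account rests on a few compounds, and the source may have more. Where it says the series, first, only, none or still open, it means among the compounds named here.

Measured in a functional assay on MCF7 cells (Homo sapiens); on this read-out higher numbers stand for weaker inhibition of growth and lower numbers for stronger inhibition of growth:
- compound 1 `O=S(=O)(/C=C/c1ccc(Cl)c(Cl)c1)Cc1ccc(Nc2ncnc3ccccc23)cc1`: 28000 nM
- compound 2 `O=S(=O)(/C=C/c1ccc(Cl)c(Cl)c1)Cc1ccc(Nc2ncnc3ccc(Br)cc23)cc1`: 14000 nM

Going by the values given here, compound 2 lies within the scatter of compound 1, the only other measured compound. Compound 3 `O=S(=O)(/C=C/c1ccc(Cl)cc1)Cc1ccc(Nc2ncnc3ccc(Br)cc23)cc1` differs from compound 2 by hydrogen in place of chloro on an aromatic carbon, so 3,4-dichlorophenyl becomes 4-chlorophenyl. Among the compounds with values here, the sole measured step, a 2.0-fold lower number from compound 1 to compound 2 (0.30 log units; within the scatter), places bromo on an aromatic carbon and involves no chloro, so it gives only weak guidance. Within the data shown here, no step beyond the scatter is therefore expected in this assay, though the data hold no direct precedent. The expected step is a 1.1-fold higher number from compound 2 to compound 3 (0.06 log units; within the scatter). The estimate for compound 3 is 16000 nM, with an expected range of 6000 nM to 40000 nM.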

Compound 3, concentration for 50% growth inhibition: 46000 nM
For compound 3 the middle estimate is 2.9-fold (0.46 log units) below the measured one; measured number above the stated range.
By their numbers in this assay, from the lowest: compounds 2, 1 and 3 (each within the scatter of the next, the first and the last beyond it).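

In this assay, going by these compounds alone, hydrogen in place of chloro gives a 3.3-fold higher number from compound 2 to compound 3 (0.52 log units; beyond the scatter), the first step to lie beyond the scatter, though a modest one. The chloro on the 3,4-dichlorophenyl group, at this place ortho to a chloro group and meta to a large group, therefore bears on growth inhibition, while the bromo step did not resolve from the scatter. No measurement on hand gives a cause for this step.

Open, on these data alone, is whether methoxy or an amine at this place would match chloro. Also open, as far as these compounds go, is whether the step holds in the core of compound 1, without bromo.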